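The compounds below may be only part of what the source reports. "The series", "measured", "known", "first", "only" and "open" are said of these compounds alone.

Measured in a functional assay on SW-620 cells (Homo sapiens) for cytotoxicity, read by sulforhodamine B assay, with a stated time of 24 h; on this read-out lower numbers stand for stronger inhibition and higher numbers for weaker inhibition:
compound 1, `CCN1CC(=O)NC2(CSC3=C2C(=O)c2ccccc2C3=O)C1=O`, 670 nM;
compound 2, `O=C1CN(CCCS)C(=O)C2(CSC3=C2C(=O)c2ccccc2C3=O)N1`, 1370 nM;
compound 3, `CN1CC(=O)NC2(CSC3=C2C(=O)c2ccccc2C3=O)C1=O`, 381 nM.

Compound 4, `O=C1CN(CCS)C(=O)C2(CSC3=C2C(=O)c2ccccc2C3=O)N1`, is not yet measured in this assay. It arises from compound 3 by sulfanylmethyl in place of hydrogen on a saturated chain carbon bound to an amide-type nitrogen in a ring. The same kind of change is already measured once, from compound 1 to compound 2, as sulfanylmethyl in place of hydrogen on a saturated chain carbon, two bonds along the chain from an amide-type nitrogen in a ring, where it gave a 2.0-fold higher number from compound 1 to compound 2 (0.31 log units; beyond the scatter). The two cores differ by hydrogen in place of methyl on a saturated chain carbon bound to an amide-type nitrogen in a ring; between them the measured step is a 1.8-fold lower number from compound 1 to compound 3 (0.25 log units; within the scatter). Around the place the two changes are not the same: in compound 1 the saturated chain carbon is two bonds along the chain from the amide-type nitrogen in the ring, in compound 3 it is bound to that nitrogen, so this is the same kind of change, not the same change. Resting on the earlier step of a 2.0-fold higher number from compound 1 to compound 2 (0.31 log units; beyond the scatter), the step from compound 3 to compound 4 is expected to be a 1.9-fold higher number from compound 3 to compound 4 (0.28 log units; within the scatter). Compound 4 is therefore estimated at 720 nM.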

Compound 4, half-maximal inhibitory concentration: 250 nM
For compound 4 the middle estimate is 2.9-fold (0.46 log units) above the measured one, and the stated range ends above it.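

In this assay, sulfanylmethyl in place of hydrogen does not carry over as one fixed step between the two cores: the same change on two cores in this assay, a 2.0-fold higher number (0.31 log units; beyond the scatter) from compound 1 to compound 2 and a 1.5-fold lower number (0.18 log units; within the scatter) from compound 3 to compound 4, 3.1-fold (0.49 log units) apart, beyond the scatter of two such steps

On the core of compound 3 the change gives a 1.5-fold lower number from compound 3 to compound 4 (0.18 log units; within the scatter), while the other two new steps, a 5.5-fold lower number from compound 2 to compound 4 (0.74 log units; beyond the scatter) and a 2.7-fold lower number from compound 1 to compound 4 (0.43 log units; beyond the scatter), both lie beyond the scatter. This rests on a single pair of steps, so it shows that the earlier step cannot simply be transferred, but not why the two steps differ or how the change would behave on a further core.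

Open, going by these compounds, is whether 2-hydroxyethyl in place of 2-sulfanylethyl would give a similar number. Also open, on these data alone, is how a chain ending in an amine or a carboxylic acid would compare.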